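The source may report more compounds than this note shows. Statements on the series, on what has been measured and on what is new or still open speak of the compounds shown alone.

Measured so far:
Compound 1, `C/C(=C\c1cc(C2=CCCCC2)co1)C(N)=O`: in an ADME assay on NIH3T3 cells (Mus musculus) for cytotoxicity, read by CCK-8 assay, with a stated time of 24 h (a higher number here means a weaker inhibitor, a lower number a stronger inhibitor), compound 1 gives > 50000 nM, which is a limit of the assay rather than a number.
Compound 2, `C/C(=C\c1cc(-c2ccccc2)cs1)C(N)=O`: in this assay compound 2 gives > 50000 nM, again a limit rather than a number.

Compound 2 therefore stands where everything measured in this assay stands, at the ceiling of the assay, since (the limit of > 50000 nM in this assay, at which 2 of the 2 values shown sit). For the measured compounds named here, no step between measured compounds that differ in a single place has been observed, so the two values alone reveal nothing about how any change shifts the reading. Compound 3, `C/C(=C\c1cc(-c2ccc(C)cc2)cs1)C(N)=O`, is the next compound to be tested, and it differs from compound 2 in one place: methyl in place of hydrogen on an aromatic carbon. With both measured values resting at a limit, no direction can be read from the numbers for this change, and no evidence points to a shift either way. The expected step is a step that the limit leaves unreadable from compound 2 to compound 3, nothing beyond the scatter of repeated measurement. Compound 3 is expected to give 60000 nM, somewhere between 30000 nM and 200000 nM, most probably reported once more only as a limit.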

Compound 3, half-maximal inhibitory concentration: > 50000 nM
Compound 3 ended at the assay's limit; the forecaster's own chance of this, stated with the estimate: 85%; the middle value does not contradict the limit.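

In this assay compound 3 gives > 50000 nM, which is a limit of the assay and not a number. The step from compound 2 to compound 3 therefore cannot be read, because all the values share one limit: the limit of > 50000 nM in this assay, at which 3 of the 3 values shown sit.

The compounds shown leave open whether any change to the shared core would give a measurable value in this assay.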